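A few compounds are considered here, and "the series" means these few. Any claim that something is new, unique, unknown or untested is made for them only; others in the source may bear on it.

Measured compounds in a functional assay on MGC-803 cells (Homo sapiens) for inhibition, read by sulforhodamine B assay; on this read-out higher numbers stand for weaker inhibition and lower numbers for stronger inhibition:
compound 1 `O=C1C=C(Nc2ccc(I)cc2)C(=O)c2c1nc1n2[C@H]2OC[C@@H](O)[C@H]2OC1`: 1400 nM
compound 2 `O=C1C(Nc2cccc(Cl)c2)=CC(=O)c2c1nc1n2[C@H]2OC[C@@H](O)[C@H]2OC1`: 1530 nM
compound 3 `O=C1C(N2CCCCC2)=CC(=O)c2c1nc1n2[C@H]2OC[C@@H](O)[C@H]2OC1`: a limit, > 4000 nM

Compound 1 and compound 2 give numbers that sit within the scatter of each other. Compound 3 reaches only the limit of the assay (the limit of > 4000 nM in this assay, at which 1 of the 3 values shown sits). For the measured compounds named here, the one step between measured neighbours, an at least 2.6-fold higher number from compound 2 to compound 3 (0.41 log units; beyond the scatter), followed the loss of an arylamino group. Compound 4 `O=C1C=C(NCc2ccccc2)C(=O)c2c1nc1n2[C@H]2OC[C@@H](O)[C@H]2OC1` differs from compound 1 by benzyl in place of 4-iodophenyl on an amine nitrogen. This change keeps the amine hydrogen that compound 3 lacks, yet moves the aromatic ring one carbon away from the nitrogen, so the step from compound 2 to compound 3 bears only partly on it. A weakening of modest size is therefore expected, a 2.1-fold higher number from compound 1 to compound 4 (0.33 log units; beyond the scatter), and compound 4 is estimated at 3000 nM, between 1200 nM and 8000 nM.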

Compound 4, half-maximal inhibitory concentration: 2670 nM
Compound 4: the middle estimate sits 1.1-fold (0.05 log units) above what was measured; the range from low to high includes it.
By their numbers in this assay, from the lowest: compounds 1, 2 and 4 (each within the scatter of the next). At a limit, above all of these: compound 3.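

Benzyl in place of 4-iodophenyl on the amine nitrogen gives a 1.9-fold higher number from compound 1 to compound 4 (0.28 log units; within the scatter), so this change leaves no difference that can be read. For this one pair, neither the iodine nor an aromatic ring bonded directly to the amine nitrogen is needed to stay out of the range of the limit. Compound 3 alone remains at a limit of the assay: the limit of > 4000 nM in this assay, at which 1 of the 4 values shown sits.

The compounds shown leave open whether the amine hydrogen or the aromatic ring accounts for that limit. A cyclohexylamino group, with its ring but no aromatic one, or a longer chain such as phenethyl, could separate the two.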